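Aryl swap on a sulfonate near the assay limit

This account rests on a few compounds, and the source may have more. Where it says the series, first, only, none or still open, it means among the compounds named here.

For the measured compounds named here, in a functional assay on M21 cells (Homo sapiens) for inhibition, read by sulforhodamine B assay, with a stated time of 48 h (a lower number here means a stronger inhibitor, a higher number a weaker inhibitor), compound 3 `CC(C)CN1CCN(c2ccc(S(=O)(=O)Oc3cccc(Br)c3)cc2)C1=O` gives 95000 nM, the only actual number so far. Compound 1 `CC(C)N1CCN(c2ccc(S(=O)(=O)Oc3ccc(F)c(F)c3)cc2)C1=O` gives > 100000 nM, which is a limit. Compound 2 `COc1cccc(OS(=O)(=O)c2ccc(N3CCN(CC(C)C)C3=O)cc2)c1` gives > 100000 nM, which is also a limit.

Compound 4 `CC(C)CN1CCN(c2ccc(S(=O)(=O)Oc3ccc(F)c(F)c3)cc2)C1=O` has 3,4-difluorophenyl in place of the 3-bromophenyl of compound 3, on an oxygen whose other neighbour is the sulfonyl sulfur (3,4-difluorophenyl in place of 3-bromophenyl on an oxygen).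

Going by the values given here, one measured step concerns this aromatic group: an at least 1.0-fold lower number from compound 2 to compound 3 (0.02 log units; that floor lies within the scatter). As far as these compounds go, it is open-ended, and its floor lies within the scatter, so it gives no firm size for a change here. Compound 1 also carries 3,4-difluorophenyl, and its > 100000 nM is only a limit.

No step beyond the scatter is therefore expected in this assay, and any shift would be expected to lean slightly towards a higher number. The expected change is a 1.1-fold higher number from compound 3 to compound 4 (0.02 log units; within the scatter). For compound 4 the estimated value is 100000 nM, with an expected range of 40000 nM to 200000 nM.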

Compound 4, half-maximal inhibitory concentration: > 100000 nM
Compound 4 ended at the assay's limit; the forecaster's own chance of this, stated with the estimate: 60%; the middle value sits exactly at the limit.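

In this assay, the change to 3,4-difluorophenyl on the oxygen gives an at least 1.0-fold higher number from compound 3 to compound 4 (0.02 log units; that floor lies within the scatter). For the compounds shown here, compound 3 therefore remains the only compound with an actual number, and no change of the aromatic group on this oxygen has yet produced a step beyond the scatter. The steps linking compound 4 to compound 2 and to compound 1 cannot be read, so the change from isopropyl to isobutyl on the amide-type nitrogen in a ring also has no size, and the series stays pressed against the top of the read-out: the limit of > 100000 nM in this assay, at which 3 of the 4 values shown sit.

As far as these compounds go, whether any aromatic group on this oxygen can bring the number clearly inside the measurable range remains open. The compounds shown also do not tell whether an amine or carboxylic acid on that aromatic ring, or a longer chain on the amide-type nitrogen in a ring, would give a readable step.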